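Sulfonyl aryl swap carried onto a second amide core

A few compounds are considered here, and "the series" means these few. Any claim that something is new, unique, unknown or untested is made for them only; others in the source may bear on it.

Compound 1 `C=C(CC)C(=O)c1ccc(OCC(=O)N2CCN(S(=O)(=O)c3ccc(OC)cc3OC)CC2)c(Cl)c1Cl` and compound 2 `C=C(CC)C(=O)c1ccc(OCC(=O)N2CCN(S(=O)(=O)c3cc(Cl)ccc3OC)CC2)c(Cl)c1Cl` share one core; compound 3 `C=C(CC)C(=O)c1ccc(OCC(=O)NC2CCN(S(=O)(=O)c3ccc(OC)cc3OC)CC2)c(Cl)c1Cl` and compound 4 `C=C(CC)C(=O)c1ccc(OCC(=O)NC2CCN(S(=O)(=O)c3cc(Cl)ccc3OC)CC2)c(Cl)c1Cl` share another. The difference between the two cores is not broken down here. In a functional assay on HL-60 cells (Homo sapiens) for cytotoxicity, read by luminescence (on this read-out lower numbers stand for stronger inhibition and higher numbers for weaker inhibition), compound 1 gives 3190 nM, and compound 2 gives 1410 nM. The change between them is 5-chloro-2-methoxyphenyl in place of 2,4-dimethoxyphenyl on a sulfonyl sulfur, and it produced a 2.3-fold lower number from compound 1 to compound 2 (0.35 log units; beyond the scatter). Compound 3 gives 860 nM in this assay, a number within the scatter of compound 2 but beyond the scatter of compound 1. Among the measured compounds shown here, compound 4 differs from compound 3 by 5-chloro-2-methoxyphenyl in place of 2,4-dimethoxyphenyl on a sulfonyl sulfur, the same change at the same place as from compound 1 to compound 2, so the measured pair serves as the one precedent. A step of roughly the same size is expected, namely a 2.2-fold lower number from compound 3 to compound 4 (0.33 log units; beyond the scatter), because the precedent was a 2.3-fold lower number from compound 1 to compound 2 (0.35 log units; beyond the scatter) and nothing else measured here bears on the swap. For the measured compounds named here, compound 4 is therefore expected to give 400 nM in this assay, with a range from 160 nM to 1000 nM reflecting that only one prior example of the change exists.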

Compound 4, half-maximal inhibitory concentration: 700 nM
Compound 4: the middle estimate sits 1.8-fold (0.24 log units) below what was measured; the measured number falls inside the stated range.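

In this assay, 5-chloro-2-methoxyphenyl in place of 2,4-dimethoxyphenyl on the sulfonyl sulfur gives a 1.2-fold lower number from compound 3 to compound 4 (0.09 log units; within the scatter), so on this core the step does not stand clear of the scatter, unlike the earlier step on the core of compound 1. The two steps cannot be told apart: the same change on two cores in this assay, a 2.3-fold lower number (0.35 log units; beyond the scatter) from compound 1 to compound 2 and a 1.2-fold lower number (0.09 log units; within the scatter) from compound 3 to compound 4, 1.8-fold (0.27 log units) apart, within the scatter of two such steps. This is compatible with the change carrying over between the two cores, but two pairs do not fix the size of the step, and they do not show that the change has any real effect on the core of compound 3.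

The compounds shown leave open how a simple methyl group or a pyridine ring on the sulfonyl sulfur would compare with these two aryl groups. They also leave open whether the chlorine or the methoxy difference carries the step, and whether the change would hold on any core beyond these two.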